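A few compounds are considered here, and "the series" means these few. Any claim that something is new, unique, unknown or untested is made for them only; others in the source may bear on it.

In a functional assay on MOLT-4 cells (Homo sapiens) for inhibition, read by MTT assay, with a stated time of 48 h (a lower number here means a stronger inhibitor, a higher number a weaker inhibitor), compound 1 `C=C(C)Cn1cc(/C=C/C(=O)CC(=O)C(=O)O)c2ccccc21` gives 40000 nM and compound 2 `O=C(/C=C/c1cn(-c2ccc(Cl)cc2)c2ccccc12)CC(=O)C(=O)O` gives 27000 nM. Within the data shown here, compound 2 therefore stands within the scatter of compound 1, the only other compound measured. Compound 3 `O=C(/C=C/c1cn(Cc2ccccc2)c2ccccc12)CC(=O)C(=O)O` carries benzyl in place of 4-chlorophenyl on an aromatic nitrogen. Among the measured compounds shown here, the only measured step at this nitrogen, a 1.5-fold lower number from compound 1 to compound 2 (0.17 log units; within the scatter), is the one guide, so no step beyond the scatter is expected in this assay. Compound 3 is estimated at 30000 nM, with an expected range from 12000 nM to 75000 nM. This estimate means an expected 1.1-fold higher number from compound 2 to compound 3 (0.05 log units; within the scatter).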

Compound 3, half-maximal inhibitory concentration: 15000 nM
Estimate against measurement, compound 3: 2.0-fold (0.30 log units) above; measured number inside the range.
By their numbers in this assay, from the lowest: compounds 3, 2 and 1 (each within the scatter of the next, the first and the last beyond it).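

Replacing 4-chlorophenyl with benzyl on the aromatic nitrogen gives a 1.8-fold lower number from compound 2 to compound 3 (0.26 log units; within the scatter) in this assay, so this change alone cannot be told apart from ordinary assay variation. Phenyl in place of 1-methylethenyl on the saturated chain carbon bound to that nitrogen gives a 2.7-fold lower number from compound 1 to compound 3 (0.43 log units; beyond the scatter), the first step at this position to clear the scatter, though only modestly. No available evidence bears on this result.

Still open, as far as these compounds go, is whether a longer chain, such as 2-phenylethyl, or an amine-bearing group on this nitrogen would lower the number further.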